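A few compounds are considered here, and "the series" means these few. Any claim that something is new, unique, unknown or untested is made for them only; others in the source may bear on it.

For the measured compounds named here, in a functional assay on VCaP cells (Homo sapiens) for antiproliferative activity, read by propidium iodide staining, with a stated time of 96 h (on this read-out higher numbers stand for weaker inhibition and lower numbers for stronger inhibition), compound 1 `CC(O)(COc1ccccc1C(F)(F)F)C(=O)Nc1ccc(S(F)(F)(F)(F)F)cc1` gives 3100 nM, the lowest of the three numbers measured so far. Compound 2 `CC(O)(COc1ccccc1OC(F)(F)F)C(=O)Nc1ccc(S(F)(F)(F)(F)F)cc1` gives 9700 nM, and compound 3 `CC(O)(COc1ccc(C#N)cc1C(F)(F)F)C(=O)Nc1ccc(S(F)(F)(F)(F)F)cc1` gives 100000 nM. Compound 4 `CC(O)(COc1ccc(C#N)c(F)c1)C(=O)Nc1ccc(S(F)(F)(F)(F)F)cc1` is not yet measured, and its structure departs from the first compound as follows: 4-cyano-3-fluorophenyl in place of 2-(trifluoromethyl)phenyl on an oxygen on a saturated carbon. Going by the values given here, two measured steps bear on this change. Trifluoromethoxy in place of trifluoromethyl came with a modest 3.1-fold higher number from compound 1 to compound 2 (0.50 log units; beyond the scatter), while cyano in place of hydrogen came with a large 32-fold higher number from compound 1 to compound 3 (1.51 log units; beyond the scatter). Compound 4 also carries a cyano group, so the second step is the closer guide, and a large move towards weaker inhibition is expected. The expected size is an estimated 9.7-fold higher number from compound 1 to compound 4 (0.99 log units; beyond the scatter). For compound 4 the estimate is 30000 nM, with an expected range from 8000 nM to 100000 nM.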

Compound 4, half-maximal inhibitory concentration: 100000 nM
Compound 4: the middle estimate sits 3.3-fold (0.52 log units) below what was measured, and the stated range covers the measured number.
By their numbers in this assay, from the lowest: compound 1; then compound 2; then compounds 3 and 4 (each within the scatter of the next).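

In this assay, 4-cyano-3-fluorophenyl in place of 2-(trifluoromethyl)phenyl on an oxygen on a saturated carbon comes with a 32-fold higher number from compound 1 to compound 4 (1.51 log units; beyond the scatter), a large step. The step is large even though compound 4 has no trifluoromethyl group, and compound 3 and compound 4 lie within the scatter of each other. No measurement shown here gives a reason for this step. The compounds shown leave open whether the step follows the nitrile or the fluorine, and whether a phenyl group with a methoxy group or an amine in place of the nitrile would stay closer to compound 1.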